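Swapping the halophenyl ring on a nucleoside sulfide

The source may report more compounds than this note shows. Statements on the series, on what has been measured and on what is new or still open speak of the compounds shown alone.

Three measured compounds share one nucleoside core and differ in the group attached to it. Compound 1 `CCCCCNc1ncnc2c1ncn2[C@@H]1O[C@H](CO)[C@@H](O)[C@H]1O` carries a pentylamino group and in an assay on isolated protein for binding affinity to Equilibrative nucleoside transporter 1 (Homo sapiens) (a higher number here means a weaker inhibitor, a lower number a stronger inhibitor), compound 1 gives 13500 nM. Compound 2 `Nc1nc(SCc2ccccc2Cl)c2ncn([C@@H]3O[C@H](CO)[C@@H](O)[C@H]3O)c2n1` carries a (2-chlorobenzyl)sulfanyl group on a different part of the core, and in this assay compound 2 gives 13500 nM. Within the data shown here, compound 3 `OC[C@H]1O[C@@H](n2cnc3c(CSc4ccccc4Br)ncnc32)[C@H](O)[C@@H]1O` carries a ((2-bromophenyl)sulfanyl)methyl group, and in this assay compound 3 gives 2400 nM; this is the lowest of the three numbers, and the only single-point step measured, a 5.6-fold lower number from compound 1 to compound 3 (0.75 log units; beyond the scatter), leads to it.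

Compound 4 `OC[C@H]1O[C@@H](n2cnc3c(CSc4cccc(I)c4)ncnc32)[C@H](O)[C@@H]1O` keeps everything in compound 3 except the halophenyl ring: 3-iodophenyl in place of 2-bromophenyl on a sulfur. Among the measured compounds shown here, no measured step changes a halogen or its position on the phenyl ring, so nothing here speaks to the size or direction of this step. A change within the scatter is therefore expected, no change at the digits printed from compound 3 to compound 4 (within the scatter), and compound 4 is estimated at 2400 nM, within a range from 800 nM to 7000 nM.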

Compound 4, half-maximal inhibitory concentration: 245 nM
The estimate for compound 4 lay 9.8-fold (0.99 log units) above the measured number; measured number outside the range, below it.
By their numbers in this assay, from the lowest: compound 4; then compound 3; then compounds 1 and 2 (each within the scatter of the next).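

In this assay the halophenyl ring on the sulfur proves to be far from a silent part of the molecule: 3-iodophenyl in place of 2-bromophenyl gives a 9.8-fold lower number from compound 3 to compound 4 (0.99 log units; beyond the scatter), a step reached without changing the rest of the compound. The same comparison against the pentylamino group widens to a 55-fold lower number from compound 1 to compound 4 (1.74 log units; beyond the scatter), so the choice of ring and halogen now counts for more than the earlier swap of the whole side group suggested. Nothing measured explains why the number falls.

This step changes both the halogen and its place on the ring, so the two effects cannot be told apart, and 3-bromophenyl or 2-iodophenyl would separate them. Going by these compounds, how a plain phenyl ring or a 3-methoxyphenyl ring would behave at this sulfur also stays open.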